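Adding bromine to the weakest compound in a small indolinone series

The compounds below may be only part of what the source reports. "The series", "measured", "known", "first", "only" and "open" are said of these compounds alone.

Of the compounds shown here, three of one shared core have been measured in a functional assay on cells (Cancer cell lines, Homo sapiens) for cytotoxicity, read by sulforhodamine B assay, with a stated time of 48 h; a lower number here means a stronger inhibitor of growth, a higher number a weaker inhibitor of growth. Compound 2 `O=C1N=C(N2N=C(c3ccccc3)CC2c2ccc(Cl)cc2)S/C1=C1/C(=O)Nc2ccccc21` gives 390 nM. Compound 3 `COc1ccc(C2=NN(C3=NC(=O)/C(=C4\C(=O)Nc5ccccc54)S3)C(c3ccc(Cl)cc3)C2)cc1` gives 100000 nM, the highest of the three numbers, and compound 1 `COc1ccc(C2=NN(C3=NC(=O)/C(=C4\C(=O)Nc5ccc(Br)cc54)S3)C(c3ccc(OC)cc3)C2)cc1` gives 25300 nM, the value nearest to it. Among the measured compounds shown here, the only single-point step among the measured compounds is a 260-fold higher number from compound 2 to compound 3 (2.41 log units; beyond the scatter), a methoxy in place of hydrogen on an aromatic carbon.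

Compound 4 `COc1ccc(C2=NN(C3=NC(=O)/C(=C4\C(=O)Nc5ccc(Br)cc54)S3)C(c3ccc(Cl)cc3)C2)cc1` differs from compound 3 by bromo in place of hydrogen on an aromatic carbon. For the measured compounds named here, no measured pair isolates this change: compound 1 carries the same bromo but differs from compound 4 elsewhere, and the bromo-bearing compound 1 and the bromo-free compound 3 differ in two places, so their two values show only that both numbers are high. Going by the values given here, the one measured step concerns a different group and gives no guide to bromine here. The author therefore expects compound 4 to stay in the weak range, with at most a modest move, estimated as a 2.2-fold lower number from compound 3 to compound 4 (0.35 log units; beyond the scatter). Compound 4 is expected to give 45000 nM in this assay, within a range from 9000 nM to 100000 nM.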

Compound 4, concentration for total growth inhibition: 7440 nM
For compound 4 the middle estimate is 6.0-fold (0.78 log units) above the measured one; measured number outside the range, below it.
By their numbers in this assay, from the lowest: compound 2; then compound 4; then compound 1; then compound 3.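

In this assay, among the compounds shown here, the earlier compounds gave no measured step at this position, and the new result shows that it is not a silent place. Bromo in place of hydrogen on an aromatic carbon of the six-membered ring, part of a fused system of two rings, gives a 13-fold lower number from compound 3 to compound 4 (1.13 log units; beyond the scatter), a large step in the direction of stronger growth inhibition, and it holds for this one pair only. With that bromo present in both compounds, chloro in place of methoxy gives a 3.4-fold lower number from compound 1 to compound 4 (0.53 log units; beyond the scatter), a modest step, while nothing shown here explains why either number moves as it does.

The compounds shown leave open whether the bromo would give a step of similar size on compound 2, which carries hydrogen at this position and lacks the methoxy of compound 3. They also leave open how fluoro, an amine or a carboxylic acid on the same aromatic carbon would compare with bromo.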